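Adding a methyl to compound 2: what to expect

The source may report more compounds than this note shows. Statements on the series, on what has been measured and on what is new or still open speak of the compounds shown alone.

Values measured so far in a physicochemical assay for lipophilicity, at pH 7.4 (a lower number here means a more polar compound, a higher number a more lipophilic compound), are these
- Compound 1 `CCOc1ccc2c(c1)C(c1cn[nH]c1)=CN(C)C(=O)[C@@H]2C` gives 3.4
- Compound 2 `CCOc1ccc2c(c1)C(c1c[nH]cn1)=CN(C)C(=O)[C@@H]2C` gives 2.7

Compound 2 holds the lower of these two numbers. Compound 3 `CCOc1ccc2c(c1)C(c1c[nH]c(C)n1)=CN(C)C(=O)[C@@H]2C` differs from it in one place. The change methyl in place of hydrogen on an aromatic carbon is methyl in place of hydrogen on an aromatic carbon, turning 1H-imidazol-4-yl into 2-methyl-1H-imidazol-4-yl. Within the data shown here, the only measured step of a number 0.70 log units lower from compound 1 to compound 2 (beyond the scatter) is a change of ring and adds no methyl, so it offers only a rough sense of scale. A modest rise in this assay is expected, an estimated a number 0.40 log units higher from compound 2 to compound 3 (beyond the scatter) in size. Compound 3 is expected at 3.1 with 2.7 to 3.5 as the estimated range.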

Compound 3, distribution coefficient: 3.1
Compound 3: middle estimate and measured number agree at the digits printed, and the stated range covers the measured number.
By their numbers in this assay, from the lowest: compound 2; then compounds 3 and 1 (each within the scatter of the next).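

In this assay, one methyl on the aromatic carbon between two ring nitrogen atoms gives a number 0.40 log units higher from compound 2 to compound 3 (beyond the scatter) and so shows that this position responds to even the smallest carbon group. The methyl also leaves a number 0.30 log units lower from compound 1 to compound 3 (within the scatter) and so the 2-methyl-1H-imidazol-4-yl and 1H-pyrazol-4-yl compounds cannot be told apart here. Nothing available explains the size of either step. Going by these compounds, whether an ethyl group or an amine on this same carbon would shift the number in the same direction remains open.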